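Ring Swap on Compound 3 and Expected Cell Toxicity

The compounds below may be only part of what the source reports. "The series", "measured", "known", "first", "only" and "open" are said of these compounds alone.

Of the compounds shown here, three sharing one core have been tested in an ADME assay on Vero cells (Chlorocebus sabaeus) for cytotoxicity, with a stated time of 72 h; on this read-out lower numbers stand for stronger inhibition and higher numbers for weaker inhibition. Compound 1 `N#Cc1ccc(-c2cccc(CO[C@@H]3COc4nc([N+](=O)[O-])cn4C3)c2)cc1` carries a nitrile-bearing aryl group; in this assay compound 1 gives only a limit of > 128000 nM. Compound 2 `O=[N+]([O-])c1cn2c(n1)OC[C@@H](OCc1csc(-c3ccc(C(F)(F)F)cc3)n1)C2` carries a trifluoromethyl group; in this assay compound 2 likewise reaches only the limit of > 128000 nM. Compound 3 `O=[N+]([O-])c1cn2c(n1)OC[C@@H](OCc1csc(-c3ccc(F)cc3)n1)C2` carries a fluoro where compound 2 carries the trifluoromethyl; in this assay compound 3 again stops at the limit of > 128000 nM. The step that the two limits leave unreadable from compound 2 to compound 3 has both ends at limits and cannot be read. Compound 3 therefore stands where every measured compound stands, at the limit with no number, as the limit of > 128000 nM in this assay, at which 3 of the 3 values shown sit, shows.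

Compound 4 `COc1ccc(-c2nc(CO[C@@H]3COc4nc([N+](=O)[O-])cn4C3)cs2)cn1` is not yet measured. It differs from compound 3 by 6-methoxypyridin-3-yl in place of 4-fluorophenyl on an aromatic carbon. For the measured compounds named here, no measured step speaks to this exchange, and the one step available is unreadable. Going by the values given here, every value so far sits at the limit, so no change beyond the scatter is expected in this assay. The step of a number no higher from compound 3 to compound 4 (the limit leaves the size open) is expected to be essentially none. Compound 4 is therefore expected to give about 128000 nM, in a range from 64000 nM to 256000 nM, most likely reported as a further limit rather than a number.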

Compound 4, half-maximal inhibitory concentration: > 128000 nM
Compound 4: only a limit was reported; the forecaster's own chance of this, stated with the estimate: 85%; the middle value sits exactly at the limit.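

In this assay, for the compounds shown here, compound 3 and compound 4 both stop at a limit, so 6-methoxypyridin-3-yl in place of 4-fluorophenyl gives no step that can be read. The compounds shown leave open what change on the shared core, if any, would give a real number rather than a limit, since all of them stand at the same point: the limit of > 128000 nM in this assay, at which 4 of the 4 values shown sit.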